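Chlorophenyl for pyridyl on the shared core: cytotoxicity outlook

The source may report more compounds than this note shows. Statements on the series, on what has been measured and on what is new or still open speak of the compounds shown alone.

Measured so far:
compound 1 `COc1ncc(-c2ccccc2)cc1[C@@H](c1ccccc1)[C@@](O)(CCN(C)C)c1cc(F)ccc1F` — "nd" (no result reported) (no result reported)
compound 2 `COc1nc(-c2ccncc2)ccc1[C@@H](c1ccccc1)[C@@](O)(CCN(C)C)c1cccc2ccccc12` — 9.6 ug/mL
compound 3 `COc1ncc(-c2ccccc2)cc1[C@@H](c1ccccc1)[C@@](O)(CCN(C)C)c1cccc(F)c1F` — 28.1 ug/mL

In a toxicity assay on HeLa cells (Homo sapiens) for cytotoxicity (on this read-out lower numbers stand for higher toxicity in this test and higher numbers for lower toxicity in this test), compound 2 gives 9.6 ug/mL, the lowest of the two numbers recorded. Compound 3 gives 28.1 ug/mL, and the gap between these two values lies beyond the usual scatter. Compound 1 stands at "nd" (no result reported) in this assay, that is, it has no reported result.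

Compound 4 `COc1nc(-c2ccc(Cl)cc2)ccc1[C@@H](c1ccccc1)[C@@](O)(CCN(C)C)c1cccc2ccccc12` is the next entry. Against compound 2 it shows (4-chlorophenyl in place of pyridin-4-yl on an aromatic carbon). For the measured compounds named here, no measured pair isolates this kind of exchange, so the step cannot be read off existing data. A modest shift toward a lower number, at the edge of the scatter, is expected a 1.5-fold lower number from compound 2 to compound 4 (0.17 log units; within the scatter). For compound 4 the estimate in this assay is 6.5 ug/mL, with a range from 3 ug/mL to 13 ug/mL.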

Compound 4, half-maximal cytotoxic concentration: > 64 ug/mL
Compound 4: no number, only a limit; the forecaster's own chance of this, stated with the estimate: 5%; middle value at least 9.8-fold (0.99 log units) from the limit.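

In this assay, 4-chlorophenyl in place of pyridin-4-yl, on the aromatic carbon next to the ring nitrogen, gives an at least 6.6-fold higher number from compound 2 to compound 4 (0.82 log units; beyond the scatter). For the compounds shown here, this is the first single-place step, and it shows that the group at this position can by itself move the read-out toward lower toxicity in this test. Compound 4 gives a limit, not a number: the limit of > 64 ug/mL in this assay, at which 1 of the 4 values shown sits.

Going by these compounds, how far the value of compound 4 lies past that limit stays open. Also open, on these data alone, is whether the chlorine or the change from pyridine nitrogen to carbon carries the step, a question that plain phenyl at this position would address.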